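Ether to hydroxy on a weakly binding bicyclic series

A few compounds are considered here, and "the series" means these few. Any claim that something is new, unique, unknown or untested is made for them only; others in the source may bear on it.

The series is a single shared core carrying an oxygen on a saturated ring carbon. Compound 1 `CCO[C@H]1CC[C@H]2CCN(C)[C@H]2C1` holds an ethyl group on that oxygen, and in an assay on HEK293 cells for displacement of a labelled ligand from Neuronal acetylcholine receptor; alpha3/beta4 (Rattus norvegicus), with a stated time of 4 h (on this read-out lower numbers stand for stronger inhibition and higher numbers for weaker inhibition), compound 1 gives 300000 nM. Compound 2 `COCCO[C@H]1CC[C@H]2CCN(C)[C@H]2C1` extends the ethyl with a methoxy; in this assay compound 2 gives 300000 nM. The step of no change at the digits printed from compound 1 to compound 2 (within the scatter) is therefore flat, and compound 2 stands level with compound 1 at the digits shown. Both numbers lie at the weak end of what this assay reports.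

Compound 3 `CN1CC[C@@H]2CC[C@H](O)C[C@@H]21` removes the chain altogether: hydrogen in place of 2-methoxyethyl on an oxygen on a saturated carbon. Going by the values given here, the one measured step that bears on the oxygen substituent, no change at the digits printed from compound 1 to compound 2 (within the scatter), moved nothing, so lengthening the chain by a methoxy left the read-out unchanged. Among the compounds with values here, there is no measured step that shortens the chain to bare hydroxy, so the expectation rests on that single flat step. On this basis no movement beyond the scatter is expected in this assay; the estimated step is no change at the digits printed from compound 2 to compound 3 (within the scatter). Compound 3 is expected to give 300000 nM, within a range of 100000 nM to 800000 nM.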

Compound 3, inhibition constant: > 300000 nM
Compound 3: a limit, no number; the forecaster's own chance of this, stated with the estimate: 35%; the middle value sits exactly at the limit.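

In this assay compound 3 gives > 300000 nM as a limit of the assay, not a number. Where the earlier compounds covered only ethers at this position, compound 3 carries the bare hydroxy. Hydrogen in place of 2-methoxyethyl gives a number no lower from compound 2 to compound 3 (the limit leaves the size open) and hydrogen in place of ethyl gives a number no lower from compound 1 to compound 3 (the limit leaves the size open) on this read-out. The sizes of both steps to compound 3 cannot be read, because the value of compound 3 is a limit: the limit of > 300000 nM in this assay, at which 1 of the 3 values shown sits.

On these data alone, whether a benzyl group or a longer chain ending in an amine on this oxygen would give a lower number stays open. So does how far compound 3 actually lies from compound 1 and compound 2.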